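This account rests on a few compounds, and the source may have more. Where it says the series, first, only, none or still open, it means among the compounds named here.

Of the compounds shown here, three built on one shared core have been measured in a functional assay on HT-29 cells (Homo sapiens) for antiproliferative activity, read by sulforhodamine B assay, with a stated time of 48 h; a lower number here means a stronger inhibitor of growth, a higher number a weaker inhibitor of growth. Compound 1 `CC(C)(C)c1ccc(-c2cc(N3CCC(CNS(N)(=O)=O)CC3)ncn2)cc1` gives 8900 nM. Compound 2 `NS(=O)(=O)NCC1CCN(c2cc(-c3ccc(Cl)cc3)ncn2)CC1` gives 37700 nM. Compound 3 `COC(=O)c1ccc(-c2cc(N3CCC(CNS(N)(=O)=O)CC3)ncn2)cc1` gives 22900 nM. Compound 2 thus stands highest of the three numbers: its nearest neighbour is compound 3, with a 1.6-fold lower number from compound 2 to compound 3 (0.22 log units; within the scatter), and its furthest is compound 1, with a 4.2-fold higher number from compound 1 to compound 2 (0.63 log units; beyond the scatter). The remaining measured step, a 2.6-fold higher number from compound 1 to compound 3 (0.41 log units; beyond the scatter), is also modest.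

Compound 4 `NS(=O)(=O)NCC1CCN(c2cc(-c3ccccc3F)ncn2)CC1` differs from compound 2 in one place: 2-fluorophenyl in place of 4-chlorophenyl on an aromatic carbon. Within the data shown here, each measured step so far exchanges one group on the phenyl ring while keeping the ring itself; here the whole 4-chlorophenyl is swapped for 2-fluorophenyl, so no measured step matches this change directly. The closest guides are the modest steps of a 4.2-fold higher number from compound 1 to compound 2 (0.63 log units; beyond the scatter) and a 1.6-fold lower number from compound 2 to compound 3 (0.22 log units; within the scatter), both of which are small, and neither of which points to a large effect from changing a halogen on that ring. For compound 4 the expected step is a 1.2-fold higher number from compound 2 to compound 4 (0.08 log units; within the scatter), which is not expected to exceed the scatter. Compound 4 is therefore estimated to give 45000 nM in this assay, with an expected range from 15000 nM to 130000 nM.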

Compound 4, concentration for 50% growth inhibition: 80400 nM
Estimate against measurement, compound 4: 1.8-fold (0.25 log units) below; the measured number falls inside the stated range.
By their numbers in this assay, from the lowest: compound 1; then compounds 3 and 2 (each within the scatter of the next); then compound 4.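

In this assay, replacing 4-chlorophenyl with 2-fluorophenyl gives a 2.1-fold higher number from compound 2 to compound 4 (0.33 log units; beyond the scatter). Among these compounds, this is the first step that alters where the substituent sits on the phenyl ring as well as what it is, since the earlier compounds differ only in the group carried in one fixed place. The two groups match in heavy-atom number, in hydrogen-bond donors and acceptors and in charge, differing in the printed counts only by the halogen, yet the number still moves beyond the scatter and places compound 4 last in the order by number, with compound 1 remaining lowest at the other end; no measurement given here accounts for this rise.

The change alters the halogen and its place on the ring at once, so the compounds shown cannot assign the rise to either alone. They also leave open how the number would read with an unsubstituted phenyl, or with an amine or a carboxylic acid on that ring.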